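The compounds below may be only part of what the source reports. "The series", "measured", "known", "first", "only" and "open" are said of these compounds alone.

Measured so far:
compound 1 `CC(Oc1ccccc1Br)C1=NCCN1`, in an assay on CHO cells for displacement of a labelled ligand from Alpha-2B adrenergic receptor (Homo sapiens); on this read-out lower numbers stand for stronger inhibition and higher numbers for weaker inhibition: 355 nM
compound 2 `CC(Oc1ccccc1S(C)(=O)=O)C1=NCCN1`, in this assay: 51300 nM

Compound 2 gives the higher of the two numbers in this assay; the step of a 140-fold higher number from compound 1 to compound 2 (2.16 log units; beyond the scatter) separates them. Compound 3 `CC(Oc1ccccc1C=O)C1=NCCN1` carries formyl in place of methylsulfonyl on an aromatic carbon. Within the data shown here, only the step from compound 1 to compound 2 bears on this change, and it was large. Since the entering group is counted smaller than the leaving one, with fewer acceptors, a step back toward the number of compound 1 is expected, though not the whole way, as compound 3 is expected to show an 8.6-fold lower number from compound 2 to compound 3 (0.93 log units; beyond the scatter). Compound 3 is therefore estimated at 6000 nM, within 1200 nM to 30000 nM.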

Compound 3, inhibition constant: 2090 nM
Estimate against measurement, compound 3: 2.9-fold (0.46 log units) above; the range from low to high includes it.
By their numbers in this assay, from the lowest: compound 1; then compound 3; then compound 2.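

In this assay, exchanging methylsulfonyl for formyl on this aromatic carbon recovers much of the rise seen with methylsulfonyl (a 25-fold lower number from compound 2 to compound 3 (1.39 log units; beyond the scatter)). The recovery is only partial, as formyl still stands short of bromo (a 5.9-fold higher number from compound 1 to compound 3 (0.77 log units; beyond the scatter)), so the three groups order as bromo, formyl, methylsulfonyl from the lowest number to the highest. No measurement shown here accounts for this order. On these data alone, whether chloro, an amine or a carboxylic acid on this carbon would come closer to bromo stays open. As far as these compounds go, whether the same order holds on other carbons of the aromatic ring also stays open.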